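Trading a Polar Side Chain for a Chlorobenzyl Group

The source may report more compounds than this note shows. Statements on the series, on what has been measured and on what is new or still open speak of the compounds shown alone.

Measured so far:
compound 1 `NCC(O)Cn1c(=O)n(C2OC(CO)[C@@H](O)[C@H]2O)c2nc(N)nc(O)c21` — 28 uM
compound 2 `C=CCn1c(=O)n(C2C=CC(CO)O2)c2nc(N)nc(O)c21` — 6 uM
compound 3 `C=CCn1c(=O)n(CCC(CCOCc2ccccc2)CCOCc2ccccc2)c2nc(N)nc(O)c21` — 7 uM

In a functional assay (B cells) with Mus musculus as the target (on this read-out higher numbers stand for an effect only at larger amounts of compound and lower numbers for an effect already at smaller amounts), compound 1 gives 28 uM, the highest of the three numbers. Compound 3 gives 7 uM and compound 2 gives 6 uM, both lower than compound 1 by more than the scatter, and both carrying an allyl group instead of the polar chain of compound 1.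

Compound 4 `Nc1nc(O)c2c(n1)n(C1OC(CO)[C@@H](O)[C@H]1O)c(=O)n2Cc1ccc(Cl)cc1` has not yet been measured. It differs from compound 1 by 4-chlorophenyl in place of 2-amino-1-hydroxyethyl on a saturated chain carbon bound to an aromatic nitrogen. Among the compounds with values here, no single step between measured compounds is available, so the size of this change is a judgement. The lower numbers of compound 2 and compound 3, which lack the polar chain, point toward a lower number for compound 4 as well. The step expected here, a 3.5-fold lower number from compound 1 to compound 4 (0.54 log units; beyond the scatter), is a drop beyond the scatter. Compound 4 is expected at 8 uM, with a range from 2 uM to 30 uM.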

Compound 4, concentration for half-maximal effect: 14 uM
Beside the measured number, compound 4's estimate is 1.8-fold (0.24 log units) below it, and the stated range covers the measured number.
By their numbers in this assay, from the lowest: compounds 2, 3, 4 and 1 (each within the scatter of the next, the first and the last beyond it).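

In this assay the swap of 3-amino-2-hydroxypropyl for 4-chlorobenzyl gives a 2.0-fold lower number from compound 1 to compound 4 (0.30 log units; within the scatter), so the two compounds cannot be told apart. At this position, then, the amino and hydroxyl groups of the chain are not required for a number in this range, and an aromatic ring of carbon only is accepted. Nothing measured here explains why the two compounds read alike.

Going by these compounds, whether a carboxylic acid or a longer alkyl chain would be accepted at this position remains open. The part played by the chlorine is also unknown.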